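Adding a chloro group beside the trifluoromethyl of compound 3

The source may hold more compounds than are shown below. What is called first, only, known or untested is meant among the compounds shown, and "the series" means these compounds.

In a functional assay on CHO cells with adenosine receptor A1 (Homo sapiens) as the target, read by cAMP accumulation and immunoassay, with a stated time of 6 min, tested at 0.1 uM (on this read-out higher numbers stand for a weaker effect at the one concentration tested and lower numbers for a stronger effect), three compounds sharing one core have been measured. Compound 1 `COc1ccc(N2CCN(Cc3csc(N)c3C(=O)c3ccc(Cl)cc3)CC2)cc1` gives 0%, compound 2 `Nc1scc(CN2CCN(c3ccc([N+](=O)[O-])cc3)CC2)c1C(=O)c1ccc(Cl)cc1` gives -13%, and compound 3 `Nc1scc(CN2CCN(c3cccc(C(F)(F)F)c3)CC2)c1C(=O)c1ccc(Cl)cc1` gives -30%. Compound 3 thus stands lowest of the three, with a number 17 percentage points lower from compound 2 to compound 3 (beyond the scatter) and a number 30 percentage points lower from compound 1 to compound 3 (beyond the scatter); both of these steps exchange the whole aryl group on the amine nitrogen in the ring, and each was modest. Compound 4 `Nc1scc(CN2CCN(c3ccc(Cl)c(C(F)(F)F)c3)CC2)c1C(=O)c1ccc(Cl)cc1` differs from compound 3 in a smaller way: chloro in place of hydrogen on an aromatic carbon, the chloro sitting ortho to a trifluoromethyl group and para to a large group. Among the compounds with values here, no measured step exchanges a hydrogen for a chloro on this ring, so none bears directly on this change; the measured steps show only that altering this aryl group moves the read-out by modest amounts, in the direction of compound 3 as the substituents change. On that basis compound 4 is expected to stay close to compound 3, with a step of about a number 5 percentage points lower from compound 3 to compound 4 (within the scatter) that may well lie within the scatter. Compound 4 is therefore estimated at -35% in this assay, in a range from -60% to -10%.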

Compound 4, a percentage reported as activity, at one concentration (the size of the read-out at that concentration, not a potency): -12%
Estimate against measurement, compound 4: 23 percentage points below; low and high end bracket the measured number.
By their numbers in this assay, from the lowest: compound 3; then compounds 2 and 4 (each within the scatter of the next); then compound 1.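

In this assay, adding a chloro on an aromatic carbon, ortho to a trifluoromethyl group and para to a large group, gives a number 18 percentage points higher from compound 3 to compound 4 (beyond the scatter), so this single heavy atom moves the read-out by a modest amount beyond the scatter, in the opposite direction to the steps that led to compound 3. Compared with the other aryl groups, the 4-chloro-3-(trifluoromethyl)phenyl group still keeps a modest separation from 4-methoxyphenyl, with a number 12 percentage points lower from compound 1 to compound 4 (beyond the scatter), but cannot be told apart from 4-nitrophenyl, with a number 1 percentage points higher from compound 2 to compound 4 (within the scatter). No measurement at hand accounts for the effect of this chloro on the read-out.

The compounds shown leave open whether this shift belongs to chloro itself or would also appear with fluoro, a methyl group or an amine on the same carbon. They also leave open whether chloro would move the read-out the same way on a phenyl ring that carries no trifluoromethyl group, and whether the step would hold at any concentration other than the one tested.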